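The source may report more compounds than this note shows. Statements on the series, on what has been measured and on what is new or still open speak of the compounds shown alone.

Measured compounds:
Compound 1, `COc1ccc(C(=O)CCN2CCN(c3ccc(C(F)(F)F)cc3)CC2)cc1`: 135000 nM
Compound 2, `COc1ccc(C(=O)CCN2CCN(c3ccc(Cl)cc3)CC2)cc1`: 300000 nM
Compound 3, `COc1ccc(C(=O)CCN2CCN(c3ccc(C(F)(F)F)cc3)CC2)cc1OC`: 243000 nM

All three were run in an ADME assay on Vero cells (Chlorocebus sabaeus) for cytotoxicity, read by resazurin assay, with a stated time of 72 h; on this read-out higher numbers stand for weaker inhibition and lower numbers for stronger inhibition. Compound 1 sits lowest of the three numbers, and the two others lie close together: compound 2 gives 300000 nM and compound 3 gives 243000 nM, a pair that falls within the usual scatter of each other, so no order between them is claimed.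

Two single changes connect these compounds. The first, (chloro in place of trifluoromethyl on an aromatic carbon), produces a 2.2-fold higher number from compound 1 to compound 2 (0.35 log units; beyond the scatter). The second, (methoxy in place of hydrogen on an aromatic carbon), produces a 1.8-fold higher number from compound 1 to compound 3 (0.26 log units; within the scatter), which does not rise above the scatter.

Compound 4, `COc1ccc(C(=O)CCN2CCN(c3ccc(Cl)cc3)CC2)cc1OC`, is not yet measured. Among the measured compounds shown here, it differs from compound 3 by chloro in place of trifluoromethyl on an aromatic carbon, and this is the same change as the one from compound 1 to compound 2, made on a core that differs from the core of compound 1 by methoxy in place of hydrogen on an aromatic carbon. The change occurs twice among the four compounds, once measured and once pending. For the measured compounds named here, since the only measured instance of this change gave a modest rise in this assay, a step of similar size is expected for compound 4 because of a 2.2-fold higher number from compound 1 to compound 2 (0.35 log units; beyond the scatter), though a single pairing is a thin base and the core difference may shift the outcome. The expected step for compound 4 is a 2.0-fold higher number from compound 3 to compound 4 (0.30 log units; within the scatter). Compound 4 is therefore estimated at 480000 nM, with a range from 240000 nM to 950000 nM.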

Compound 4, half-maximal inhibitory concentration: 185000 nM
Estimate against measurement, compound 4: 2.6-fold (0.41 log units) above; measured number outside the range, below it.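

In this assay, chloro in place of trifluoromethyl does not carry over from the core of compound 1 to the core with the added methoxy, where it gives a 1.3-fold lower number from compound 3 to compound 4 (0.12 log units; within the scatter), and the gap between the two steps exceeds what scatter would account for: the same change on two cores in this assay, a 2.2-fold higher number (0.35 log units; beyond the scatter) from compound 1 to compound 2 and a 1.3-fold lower number (0.12 log units; within the scatter) from compound 3 to compound 4, 2.9-fold (0.47 log units) apart, beyond the scatter of two such steps

Read the other way round, methoxy in place of hydrogen on the chloro-bearing core gives a 1.6-fold lower number from compound 2 to compound 4 (0.21 log units; within the scatter), so that change does not carry over either: the same change on two cores in this assay, a 1.8-fold higher number (0.26 log units; within the scatter) from compound 1 to compound 3 and a 1.6-fold lower number (0.21 log units; within the scatter) from compound 2 to compound 4, 2.9-fold (0.47 log units) apart, beyond the scatter of two such steps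

Both comparisons rest on the same four compounds and are one finding seen from two sides: in this set the two changes do not simply add up, so a step measured on one core is a poor guide to the step on the other, but neither new step rises above the scatter alone, and the data do not show why the steps differ or how any further core would behave.

The compounds shown leave open whether a fluoro or a nitrile in place of the chloro would follow the step seen on the core of compound 1 or the one seen on the methoxy-bearing core. They also leave open whether the same mismatch would appear with a longer chain carrying the carbonyl.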